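From 3-nitrophenyl to 2-chloro-4-fluorophenyl on a shared core

The compounds below may be only part of what the source reports. "The series", "measured", "known", "first", "only" and "open" are said of these compounds alone.

In a functional assay on HepG2 cells (Homo sapiens) for antiproliferative activity, read by MTT assay, with a stated time of 72 h (a higher number here means a weaker inhibitor, a lower number a stronger inhibitor), compound 1 `O=C(N/N=C/c1ccc(Br)cc1)Nc1ccc(Oc2ccnc3[nH]ccc23)c(F)c1` gives 1000 nM while compound 2 `O=C(N/N=C/c1cccc([N+](=O)[O-])c1)Nc1ccc(Oc2ccnc3[nH]ccc23)c(F)c1` gives 5180 nM as the higher of the two numbers, which makes it the weaker inhibitor so far. Going by the values given here, the one measured step is a 5.2-fold higher number from compound 1 to compound 2 (0.71 log units; beyond the scatter) and it came with 3-nitrophenyl in place of 4-bromophenyl. Compound 3 `O=C(N/N=C/c1ccc(F)cc1Cl)Nc1ccc(Oc2ccnc3[nH]ccc23)c(F)c1` changes the same spot, with 2-chloro-4-fluorophenyl in place of 3-nitrophenyl on a carbon with a double bond to nitrogen gives the full count of that swap. Its ring carries halogens, like that of compound 1 at 1000 nM so a partial return toward that number is expected. The expected change is a modest move to a lower number, a 2.9-fold lower number from compound 2 to compound 3 (0.46 log units; beyond the scatter) in this assay and it rests on a single step, so it remains uncertain. Compound 3 is estimated at 1800 nM with an expected range from 600 nM to 4800 nM.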

Compound 3, half-maximal inhibitory concentration: 1110 nM
The estimate for compound 3 lay 1.6-fold (0.21 log units) above the measured number; the range from low to high includes it.
By their numbers in this assay, from the lowest: compounds 1 and 3 (each within the scatter of the next); then compound 2.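

In this assay the step to 2-chloro-4-fluorophenyl gives a 4.7-fold lower number from compound 2 to compound 3 (0.67 log units; beyond the scatter) and so shows that the higher number of compound 2 is not the fixed outcome of moving away from 4-bromophenyl at this position. The two halogen-carrying rings cannot be told apart here, with a 1.1-fold higher number from compound 1 to compound 3 (0.05 log units; within the scatter) and so the 3-nitrophenyl ring alone stands apart among these three compounds. Nothing measured here explains that difference.

As far as these compounds go, it remains open whether a plain phenyl ring, or a phenyl ring carrying an amine or a carboxylic acid, would sit with compound 1 and compound 3 or with compound 2. From the compounds shown here alone, it is also open whether an aromatic ring is needed on this carbon at all, or whether a simple alkyl chain could take its place.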